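The compounds below may be only part of what the source reports. "The series", "measured", "known", "first", "only" and "open" are said of these compounds alone.

Compound 1 `CC1(/C=C/c2ccc(C(F)(F)F)cc2)C=CC(=O)O1`: 652000 nM
Compound 2 `COc1cc(/C=C/C2(C)C=CC(=O)O2)cc(OC)c1OC`: > 1000000 nM
Compound 3 `COc1cccc(/C=C/C2(C)C=CC(=O)O2)c1`: > 1000000 nM

Within the data shown here, in a functional assay on K562 cells (Homo sapiens) for inhibition, read by sulforhodamine B assay, with a stated time of 48 h (on this read-out lower numbers stand for stronger inhibition of growth and higher numbers for weaker inhibition of growth), compound 1 gives 652000 nM, the only true number in this small set. Compound 2 reads > 1000000 nM, which is a limit of the assay. Compound 3 reads > 1000000 nM, which is also a limit.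

Compound 4 `COc1ccc(/C=C/C2(C)C=CC(=O)O2)cc1` has not been measured. It differs from compound 1 by methoxy in place of trifluoromethyl on an aromatic carbon. Compound 2 and compound 3 both carry methoxy groups, so the expectation leans on (the limit of > 1000000 nM in this assay, at which 2 of the 3 values shown sit). In this assay, a modest move toward weaker inhibition of growth is expected, and the assay may report only its limit. The expected change is a 1.5-fold higher number from compound 1 to compound 4 (0.19 log units; within the scatter). For compound 4 the estimate is 1000000 nM, with an expected range of 600000 nM to 1500000 nM.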

Compound 4, concentration for total growth inhibition: > 1000000 nM
Compound 4 gave a limit, no number (the forecaster's own chance of this, stated with the estimate: 70%); the middle value lies on the limit itself.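

Among these compounds, compound 1 and compound 4 are the first pair here that differ in one place, so in this assay the change to methoxy on this aromatic carbon can be read directly as an at least 1.5-fold higher number from compound 1 to compound 4 (0.18 log units; that floor lies within the scatter) and not as an exact size. Compound 4 reads > 1000000 nM as a limit of the assay and not a number. The step is therefore only a floor, and compound 4 sits where most of this small set sits: the limit of > 1000000 nM in this assay, at which 3 of the 4 values shown sit.

Going by these compounds, how far compound 4 lies past its limit stays open, so the true size of the change is unknown. Also open, on these data alone, is how chlorine, an amine or a carboxylic acid would read at this position.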